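The compounds below may be only part of what the source reports. "The series", "measured", "known", "first", "only" and "open" are said of these compounds alone.

In a functional assay on HeLa cells (Homo sapiens) for antiproliferative activity, read by MTT assay, with a stated time of 48 h (on this read-out lower numbers stand for stronger inhibition and higher numbers for weaker inhibition), compound 1 `CCN(CC)CCn1c(N)c(-c2nc3ccccc3[nH]2)c2nc(C#N)c(C#N)nc21` gives 11600 nM, the higher of the two plain numbers in hand; compound 3 `CCN(CC)CCCn1c(N)c(-c2nc3ccccc3[nH]2)c2nc(C#N)c(C#N)nc21` gives 3150 nM. Compound 2 `CCCn1c(N)c(-c2nc3ccccc3[nH]2)c2nc(C#N)c(C#N)nc21` reaches only the assay limit of > 50000 nM. Compound 4 `N#Cc1nc2c(-c3nc4ccccc4[nH]3)c(N)n(CCCO)c2nc1C#N` differs from compound 1 by hydroxymethyl in place of diethylamino on a saturated chain carbon, two bonds along the chain from an aromatic nitrogen. Among the measured compounds shown here, two measured steps bear on this change: methyl in place of diethylamino gave an at least 4.3-fold higher number from compound 1 to compound 2 (0.63 log units; beyond the scatter), while (diethylamino)methyl in place of diethylamino gave a 3.7-fold lower number from compound 1 to compound 3 (0.57 log units; beyond the scatter); the gap between those two products was an at least 15-fold lower number from compound 2 to compound 3 (1.20 log units; beyond the scatter). For compound 4 a clear rise in the number is expected because loss of the diethylamino group gave an at least 4.3-fold higher number from compound 1 to compound 2 (0.63 log units; beyond the scatter) and that group leaves here as well. The estimated step is a 3.4-fold higher number from compound 1 to compound 4 (0.54 log units; beyond the scatter). Compound 4 is therefore expected at 40000 nM, between 15000 nM and 100000 nM.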

Compound 4, half-maximal inhibitory concentration: > 50000 nM
Compound 4 gave a limit, no number (the forecaster's own chance of this, stated with the estimate: 40%); middle value at least 1.2-fold (0.09 log units) from the limit.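

A hydroxy group at the end of the chain does not take over from the diethylamino group in this assay: the change gives an at least 4.3-fold higher number from compound 1 to compound 4 (0.63 log units; beyond the scatter), and the swap that keeps the chain length gives an at least 15-fold higher number from compound 3 to compound 4 (1.20 log units; beyond the scatter). The result for compound 4 is a limit, not a number. The step between compound 2 and compound 4 cannot be read because both sit at the same limit: the limit of > 50000 nM in this assay, at which 2 of the 4 values shown sit.

As far as these compounds go, it remains open whether another amine on this chain, such as dimethylamino or piperidine, would match compound 3. From the compounds shown here alone, how a carboxylic acid at the chain end would behave also remains open.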